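Two Drawn Stereocentres Lose Their Configuration in Compound 3

The source may report more compounds than this note shows. Statements on the series, on what has been measured and on what is new or still open speak of the compounds shown alone.

In a functional assay on RAW264.7 cells (Mus musculus) for inhibition, read by Griess assay, with stated times of 2 h and 24 h (on this read-out lower numbers stand for stronger inhibition and higher numbers for weaker inhibition), compound 1 (`CO[C@@H]1CC/C(C)=C/CC(C)(C)/C=C/C(=O)[C@H]1CO`) gives 27200 nM, and compound 2 (`CO[C@H]1CC/C(C)=C/CC(C)(C)/C=C/C(=O)[C@@H]1CO`) gives 41400 nM. These two numbers are the only ones available so far, and they lie within the scatter of each other, so compound 2 stands level with compound 1 on this read-out.

The next compound, compound 3 (`COC1CC/C(C)=C/CC(C)(C)/C=C/C(=O)C1CO`), is compared with compound 2: the two compounds have the same atoms and bonds; at least one stereo element is drawn with a configuration in one of them and without one in the other: 2 of 4 stereo elements differ; a stereocentre at a saturated ring carbon is drawn S in compound 2 and without a configuration in compound 3; a stereocentre at a saturated ring carbon is drawn R in compound 2 and without a configuration in compound 3. Put simply, the two compounds have the same atoms and bonds, but two stereocentres at saturated ring carbons are drawn without a configuration in compound 3.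

Among the compounds with values here, one measured step bears on this change: a 1.5-fold higher number from compound 1 to compound 2 (0.18 log units; within the scatter). It is informative given (the fact that compounds 1 and 2 differ only in the configuration as drawn). Reversing both drawn stereocentres therefore produced no change beyond the scatter in this assay, so a compound drawn without those configurations has no clear reason to move in either direction.

The estimated step is a 1.2-fold lower number from compound 2 to compound 3 (0.09 log units; within the scatter), which is expected to stay within the scatter. For compound 3, the expected value is 34000 nM, with an estimated range from 21000 nM to 56000 nM.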

Compound 3, half-maximal inhibitory concentration: 18100 nM
Beside the measured number, compound 3's estimate is 1.9-fold (0.27 log units) above it, outside the stated range (below it).
By their numbers in this assay, from the lowest: compounds 3, 1 and 2 (each within the scatter of the next, the first and the last beyond it).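

Within the data shown here, until now, reversing the two drawn stereocentres had given no step beyond the scatter, but in this assay leaving them undefined gives a modest one, a 2.3-fold lower number from compound 2 to compound 3 (0.36 log units; beyond the scatter), and this is the only structural difference in that pair: the fact that one of compounds 2 and 3 is drawn with a defined configuration and the other without, at the place where they differ The matching step from the mirror-drawn arrangement at these two ring carbons is a 1.5-fold lower number from compound 1 to compound 3 (0.18 log units; within the scatter), which stays within the scatter even though the structural difference is of the same kind: the fact that one of compounds 1 and 3 is drawn with a defined configuration and the other without, at the place where they differ Taken together, the three compounds show only a slight dependence on how these two stereocentres are drawn, and the one step beyond the scatter appears in a single pair, so it does not establish a general effect of leaving them undefined.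

The drawing of compound 3 does not tell which arrangements at these two ring carbons its sample holds, so the source of its lower number compared with compound 2 remains unresolved. All three compounds share the same atoms and bonds, so they cannot show how this read-out would respond to an amine or a carboxylic acid on the shared core.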